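Replacing the Cyanophenyl Group with a Simple Carbamoyl

The source may hold more compounds than are shown below. What is called first, only, known or untested is meant among the compounds shown, and "the series" means these compounds.

Going by the values given here, compound 2 `N#Cc1ccc(Cn2c(=O)n(C3OC(CO)[C@@H](O)[C@H]3O)c3nc(N)nc(O)c32)cc1` stands lowest of the two numbers so far in a functional assay (B cells) with Mus musculus as the target (a lower number here means that less compound is needed, a higher number that more compound is needed for the effect), where compound 2 gives 15 uM. Compound 1 `Nc1nc(O)c2c(n1)n(C1OC(CO)[C@@H](O)[C@H]1O)c(=O)n2C/C=C/c1ccccc1` gives 103 uM in this assay; the step of a 6.9-fold lower number from compound 1 to compound 2 (0.84 log units; beyond the scatter) is a modest one and lies beyond the scatter. Compound 3 `NC(=O)Cn1c(=O)n(C2OC(CO)[C@@H](O)[C@H]2O)c2nc(N)nc(O)c21` differs from compound 2 by carbamoyl in place of 4-cyanophenyl on a saturated chain carbon bound to an aromatic nitrogen. Among the compounds with values here, no measured step exchanges an aromatic group at this position for a small open-chain group, so the single step from compound 1 to compound 2 is the only guide, and it bears on the present change only indirectly: both measured compounds carry a ring at this place, and compound 3 carries none. Within the data shown here, a step toward a higher number is expected, of roughly the size of the one step seen, because a 6.9-fold lower number from compound 1 to compound 2 (0.84 log units; beyond the scatter) is the only change measured at this position and shows the number shifting well beyond the scatter. For compound 3 the estimated step is a 4.0-fold higher number from compound 2 to compound 3 (0.60 log units; beyond the scatter). Compound 3 is therefore expected to give 60 uM in this assay, within 15 uM to 300 uM.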

Compound 3, concentration for half-maximal effect: 190 uM
Estimate against measurement, compound 3: 3.2-fold (0.50 log units) below; the range from low to high includes it.
By their numbers in this assay, from the lowest: compound 2; then compounds 1 and 3 (each within the scatter of the next).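

In this assay, carbamoyl in place of 4-cyanophenyl on a saturated chain carbon bound to an aromatic nitrogen gives a 13-fold higher number from compound 2 to compound 3 (1.10 log units; beyond the scatter), the largest step yet seen at this position, so the low number of compound 2 is lost with this exchange. The other comparison, a 1.8-fold higher number from compound 1 to compound 3 (0.27 log units; within the scatter), shows that compound 3, with no ring in this group, cannot be told apart from compound 1, which carries 2-phenylethenyl, so a ring in the group is not enough on its own to give a low number, and among these three groups only 4-cyanophenyl stands apart. Nothing measured here explains why these groups differ in this way.

The compounds shown leave open whether the low number of compound 2 depends on the nitrile or on the benzyl frame that carries it, a question that an unsubstituted benzyl group at this place would help to separate. They also leave open how a carboxylic acid, an amine or a longer chain in place of carbamoyl would compare with compound 3.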